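The source may hold more compounds than are shown below. What is called first, only, known or untested is meant among the compounds shown, and "the series" means these compounds.

Of the compounds shown here, three have been measured in an in vitro functional assay on 1321-N1 cells for agonist activity at Free fatty acid receptor 1 (Homo sapiens), read by fluorescence, spectrophotometry and calcium flux; a higher number here means a larger maximal response, a lower number a smaller maximal response. Compound 1 `O=C(O)C1CC1c1ccc(C#Cc2cc(Cl)nc(Cl)c2)cc1` gives 96%, compound 2 `Cc1c(C#Cc2ccc(CCC(=O)O)cc2)cc(Cl)nc1Cl` gives 91%, and compound 3 `Cc1ccccc1-c1cc(C#Cc2ccc(CCC(=O)O)cc2)ccn1` gives 92%. Among these numbers compound 2 stands at the smallest one, yet the gap to compound 3 and the gap to compound 1 both lie within the usual scatter of this assay, so the three cannot be told apart on the numbers shown.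

Compound 4 `Cc1c(C#Cc2ccc(CCC(=O)O)cc2)ccnc1Cl` has not yet been measured in this assay. It differs from compound 2 in one place: hydrogen in place of chloro on an aromatic carbon. The change sits on an aromatic carbon of a six-membered aromatic ring with one nitrogen, next to the ring nitrogen and para to the methyl group.

Among the measured compounds shown here, no measured pair shows this change, so the expectation rests on the three measured compounds alone, all of which reach a similar maximal response. Compound 4 is therefore estimated to give 88%, with a range from 70% to 100%. The expected step of a number 3 percentage points lower from compound 2 to compound 4 (within the scatter) is none beyond the scatter.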

Compound 4, largest response reached (reported as efficacy), in percent of the reference or control that the assay uses: 101%
The estimate for compound 4 lay 13 percentage points below the measured number; measured number above the stated range.
By their numbers in this assay, from the lowest: compounds 2, 3, 1 and 4 (each within the scatter of the next).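

In this assay, hydrogen in place of chloro on the aromatic carbon next to the ring nitrogen gives a number 10 percentage points higher from compound 2 to compound 4 (within the scatter), so the maximal response at this position does not depend on that chloro. The step says this of one chloro group only, since the chloro meta to this place is still present in compound 4. No evidence at hand bears on this result.

From the compounds shown here alone, it remains open whether a methoxy group or an amine on this same carbon would leave the maximal response intact, and whether hydrogen could also replace the remaining chloro. The compounds shown also leave open how this change affects the concentration needed to reach that response, as only the largest response is given here.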